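Cell tolerance across the series: from compound 1 to compound 4

A few compounds are considered here, and "the series" means these few. Any claim that something is new, unique, unknown or untested is made for them only; others in the source may bear on it.

Compound 1 `COc1ccc(-c2cc(Cl)cn3c([N+](=O)[O-])c(CS(=O)(=O)c4ccccc4)nc23)cc1` stands on only a limit in an ADME assay on HepG2 cells (Homo sapiens) for cytotoxicity, read by MTT assay, with a stated time of 72 h; a higher number here means that more compound is tolerated, a lower number that less compound is tolerated. In this assay compound 1 gives > 3900 nM, a limit of the assay and not a number. Compound 2 `CCN(CC)c1ccc(-c2cc(Cl)cn3c([N+](=O)[O-])c(CS(=O)(=O)c4ccccc4)nc23)cc1`, with diethylamino in place of methoxy on an aromatic carbon, gives > 15600 nM in this assay, again a limit. Compound 3 `O=[N+]([O-])c1c(CS(=O)(=O)c2ccccc2)nc2c(-c3ccc(O)cc3)cc(Cl)cn12`, with hydrogen in place of methyl on an oxygen on an aromatic ring, gives > 12500 nM in this assay, also a limit. All three readings are limits, so none of the steps can be sized: a step that the two limits leave unreadable from compound 1 to compound 2, a step that the two limits leave unreadable from compound 1 to compound 3 and a step that the two limits leave unreadable from compound 2 to compound 3. What the three do share is that every compound was tolerated up to the limit reached, whether (the limit of > 3900 nM in this assay, at which 1 of the 3 values shown sits), the limit of > 12500 nM in this assay, at which 1 of the 3 values shown sits, or (the limit of > 15600 nM in this assay, at which 1 of the 3 values shown sits).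

Compound 4 `O=[N+]([O-])c1c(CS(=O)(=O)c2ccccc2)nc2c(-c3ccc(CO)cc3)cc(Cl)cn12` differs from compound 1 by hydroxymethyl in place of methoxy on an aromatic carbon. For the measured compounds named here, no measured step bears directly on this change; the three changes made at the same aromatic carbon all left tolerance at a limit, so no direction beyond the scatter can be read for the step in this assay, and a further limit is expected. Compound 4 is estimated at 10000 nM, with a range from 3900 nM to 25000 nM. The step from compound 1 to compound 4 is therefore expected as a step that the limit leaves unreadable from compound 1 to compound 4.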

Compound 4, half-maximal cytotoxic concentration: 13100 nM
Compound 4: the middle estimate sits 1.3-fold (0.12 log units) below what was measured, and the stated range covers the measured number.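

For the compounds shown here, compound 4 gives 13100 nM in this assay, the first actual number for a group at this aromatic carbon. The other three compounds stand only on limits. Going by these compounds alone, the one readable step is an at least 1.1-fold lower number from compound 2 to compound 4 (0.07 log units; that floor lies within the scatter), so hydroxymethyl in place of diethylamino shows no separation beyond the scatter, while the steps to compound 4 from compound 1 and from compound 3 cannot be read. The evidence at hand gives no reason why 4-(hydroxymethyl)phenyl yields a number where 4-methoxyphenyl yields a limit.

Still open, as far as these compounds go, is where compound 1, compound 2 and compound 3 would fall relative to compound 4 if their limits were replaced by numbers, so the rank of these groups on the shared core cannot be stated. Also open, from the compounds shown here alone, is whether an aminomethyl group, a carboxylic acid or a longer chain such as hydroxyethyl at this aromatic carbon would give a number close to that of compound 4 or one clearly apart from it.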